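Bromo Substitution on the Oxindole Ring of Compound 2

The source may hold more compounds than are shown below. What is called first, only, known or untested is meant among the compounds shown, and "the series" means these compounds.

Two compounds from a series of oxindole-derived pyrazoline hybrids have been examined in a functional assay on cells (Cancer cell lines, Homo sapiens) for cytotoxicity, read by sulforhodamine B assay, with a stated time of 48 h; on this read-out lower numbers stand for stronger inhibition of growth and higher numbers for weaker inhibition of growth. Compound 1 `COc1ccc(C2CC(c3ccccc3)=NN2C2=NC(=O)/C(=C3\C(=O)Nc4ccc(Br)cc43)S2)cc1` gives 390 nM in this assay. Compound 2 `COc1ccc(C2CC(c3ccc4ccccc4c3)=NN2C2=NC(=O)/C(=C3\C(=O)Nc4ccccc43)S2)cc1` gives 12400 nM in this assay, the highest of the two numbers; its nearest neighbour is compound 1, whose number lies well beyond the scatter of repeated measurements. The two compounds differ in more than one place, so only their two values can be compared. Compound 3 `COc1ccc(C2CC(c3ccc4ccccc4c3)=NN2C2=NC(=O)/C(=C3\C(=O)Nc4ccc(Br)cc43)S2)cc1` has not been measured. It differs from compound 2 by bromo in place of hydrogen on an aromatic carbon. For the measured compounds named here, no single-change step between measured compounds is available, so the expectation rests on the two values alone. Compound 3 is expected to show a moderate step toward stronger inhibition, a 3.5-fold lower number from compound 2 to compound 3 (0.55 log units; beyond the scatter), with an estimated value of 3500 nM in this assay, in a range from 800 nM to 14000 nM.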

Compound 3, concentration for total growth inhibition: 140 nM
Compound 3: the middle estimate sits 25-fold (1.40 log units) above what was measured; the measured number lies below the stated range.
By their numbers in this assay, from the lowest: compound 3; then compound 1; then compound 2.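

In this assay, for the compounds shown here, bromo in place of hydrogen on an aromatic carbon, meta to a fused ring and para to a fused ring, gives an 89-fold lower number from compound 2 to compound 3 (1.95 log units; beyond the scatter) and so provides the first single-change reading at this position, a large step. With the bromo kept, naphthalen-2-yl in place of phenyl on a carbon with a double bond to nitrogen gives a 2.8-fold lower number from compound 1 to compound 3 (0.44 log units; beyond the scatter), a modest step, so among these compounds the bromo change is the larger of the two. No measurement available here explains either step.

The compounds shown leave open whether the bromo step would be as large with phenyl in place of naphthalen-2-yl. They also leave open how chloro, nitrile or an amine on the same aromatic carbon would compare with bromo.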